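The source may hold more compounds than are shown below. What is called first, only, known or untested is meant among the compounds shown, and "the series" means these compounds.

Compound 1 `O=C1NC(=O)N(/N=C/c2ccc(-c3ccc(Cl)c(Cl)c3)o2)C1O`: 34 mg/kg
Compound 2 `N#Cc1ccc(-c2ccc(/C=N/N3C(=O)NC(=O)C3O)o2)cc1`: 743 mg/kg
Compound 3 `O=C1CN(/N=C/c2ccc(-c3cccc(C(F)(F)F)c3)o2)C(=O)N1`: 184 mg/kg

All three compounds were tested in a functional assay on the whole organism (Tail) for activation, with Mus musculus as the target, with a stated time of 1 min; on this read-out higher numbers stand for an effect only at larger amounts of compound and lower numbers for an effect already at smaller amounts. Compound 2 has the highest number of the three, so it shows its effect only at the largest dose. Its gaps to the other two lie beyond the usual scatter of repeated measurements: compound 3 stands nearest to it and compound 1 furthest.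

The next compound, compound 4 `O=C1NC(=O)N(/N=C/c2ccc(-c3ccc([N+](=O)[O-])cc3)o2)C1O`, keeps everything in compound 2 except one group, with nitro in place of cyano on an aromatic carbon, para to a large group: nitro in place of cyano on an aromatic carbon.

Going by the values given here, no pair of measured compounds differs by this exchange alone, so the data give no direct guide to its size. Compound 1 shares the core of compound 2. Compound 2 gives 743 mg/kg and compound 1 gives 34 mg/kg, which shows how far numbers on this core can lie apart. A moderate fall in the number is expected, though it may only just clear the scatter, and a much larger move cannot be excluded. The expected change is a 2.5-fold lower number from compound 2 to compound 4 (0.39 log units; beyond the scatter). For compound 4 the estimated dose is 300 mg/kg, with an expected range of 70 mg/kg to 1000 mg/kg.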

Compound 4, dose for half-maximal effect: > 1000 mg/kg
Compound 4: no number, only a limit; the forecaster's own chance of this, stated with the estimate: 10%; middle value at least 3.3-fold (0.52 log units) from the limit.
By their numbers in this assay, from the lowest: compound 1; then compound 3; then compound 2. At a limit, above all of these: compound 4.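

In this assay, going by these compounds alone, this is the first reading of a single exchange at this position, on an aromatic carbon para to a large group, and it gives an at least 1.3-fold higher number from compound 2 to compound 4 (0.12 log units; that floor lies within the scatter). Compound 4 has no true number here, only a limit of the assay: the limit of > 1000 mg/kg in this assay, at which 1 of the 4 values shown sits. What this adds is that, with the rest of compound 2 kept, nitro in place of cyano brings no shift towards smaller doses, and the step has a floor but no upper end, so its real size may be small or large.

The floor of this step lies within the usual scatter, so the data cannot say how far compound 4 truly stands from compound 2, and this one exchange gives no rule for other groups at this position. The compounds shown also leave open what an amine, a carboxylic acid or a simple methyl group would do at this same place on the core shared by compound 2 and compound 4, and whether any of them would bring the dose down or leave it as high as with cyano or nitro.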